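A few compounds are considered here, and "the series" means these few. Any claim that something is new, unique, unknown or untested is made for them only; others in the source may bear on it.

Compound 1 `CCn1c(C(=O)NCCO)ccc1C(CC)(CC)c1ccc(OCS(=O)(=O)c2ccccc2)c(C)c1` carries a 2-hydroxyethyl group on its amide nitrogen. In a functional assay on PC-3 cells (Homo sapiens) for antiproliferative activity, read by MTT assay, with a stated time of 24 h (a higher number here means a weaker inhibitor, a lower number a stronger inhibitor), compound 1 gives 17700 nM. For the measured compounds named here, only one other compound has been measured alongside it: compound 2 `CCn1c(C(=O)NCC(=O)O)ccc1C(CC)(CC)c1ccc(OCS(=O)(=O)c2ccccc2)c(C)c1`, in which a carboxy group replaces the hydroxymethyl on the chain carbon bound to the amide nitrogen, and in this assay compound 2 gives 30100 nM. Going by the values given here, the step of a 1.7-fold higher number from compound 1 to compound 2 (0.23 log units; within the scatter) is the only comparison available, and it shows that swapping a hydroxyl for a carboxylic acid at this end of the molecule made no difference that the assay can resolve.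

Compound 3 `CCn1c(C(=O)N[C@H](C(=O)O)C(C)C)ccc1C(CC)(CC)c1ccc(OCS(=O)(=O)c2ccccc2)c(C)c1` changes the same amide substituent again: 1-carboxy-2-methylpropyl in place of 2-hydroxyethyl on an amide-type nitrogen. The new group keeps the carboxylic acid of compound 2 and adds a branched carbon chain. Because the step of a 1.7-fold higher number from compound 1 to compound 2 (0.23 log units; within the scatter) stayed within the scatter, the expected step of a 1.4-fold higher number from compound 1 to compound 3 (0.15 log units; within the scatter) is likewise small, with no clear direction. Compound 3 is therefore estimated at 25000 nM, within a range of 10000 nM to 60000 nM.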

Compound 3, half-maximal inhibitory concentration: 3650 nM
The estimate for compound 3 lay 6.8-fold (0.84 log units) above the measured number; the whole stated range lies above it.
By their numbers in this assay, from the lowest: compound 3; then compounds 1 and 2 (each within the scatter of the next).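

In this assay the amide substituent turns out to matter after all: the step of a 4.8-fold lower number from compound 1 to compound 3 (0.69 log units; beyond the scatter) lies beyond the scatter, which the earlier pair gave no sign of. The carboxylic acid alone does not set compound 3 apart, since compound 2 carries it too; the only difference there is isopropyl in place of hydrogen on the saturated chain carbon bound to the amide-type nitrogen and the carbonyl carbon, and it brings the step of an 8.2-fold lower number from compound 2 to compound 3 (0.92 log units; beyond the scatter) within this pair. No measurement shown here explains this gain.

On these data alone, whether the branch must be isopropyl stays open, as a methyl or a benzyl group on that carbon could give a different number. Also open, as far as these compounds go, are the opposite configuration at the stereocentre and whether the isopropyl branch would act the same with a hydroxymethyl in place of the carboxylic acid.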